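The source may report more compounds than this note shows. Statements on the series, on what has been measured and on what is new or still open speak of the compounds shown alone.

In a functional assay on KB 3-1 cells (Homo sapiens) for cytotoxicity, read by MTT assay, with a stated time of 72 h (on this read-out higher numbers stand for weaker inhibition and lower numbers for stronger inhibition), compound 3 `C=CCNC(=S)N/N=C1\C(=O)Nc2ccccc21` gives 26100 nM, the higher of the two actual numbers in this small set. Compound 1 `O=C1Nc2ccccc2/C1=N/NC(=S)Nc1cccc2ccccc12` gives 5120 nM, lower by more than the scatter. Compound 2 `O=C1Nc2ccccc2/C1=N/NC(=S)Nc1cccnc1` reaches only a limit of the assay, > 50000 nM. Going by the values given here, the one measured step, an at least 1.9-fold lower number from compound 2 to compound 3 (0.28 log units; that floor lies within the scatter), rests on that limit and gives no firm size. Compound 4 `O=C1Nc2ccccc2/C1=N/NC(=S)Nc1cccc(Cl)c1` differs through (3-chlorophenyl in place of allyl on an amide-type nitrogen), with 3-chlorophenyl in place of allyl on an amide-type nitrogen. Among the aromatic groups at that nitrogen, compound 1 at 5120 nM favours a lower number, while compound 2 goes against it. A moderate fall is therefore expected in this assay, with the expected change being a 2.6-fold lower number from compound 3 to compound 4 (0.42 log units; beyond the scatter). For compound 4 the estimate is 10000 nM, with an expected range of 3000 nM to 35000 nM.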

Compound 4, half-maximal inhibitory concentration: 1870 nM
For compound 4 the middle estimate is 5.3-fold (0.73 log units) above the measured one, outside the stated range (below it).
By their numbers in this assay, from the lowest: compound 4; then compound 1; then compound 3. At a limit, above all of these: compound 2.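

In this assay, going by these compounds alone, 3-chlorophenyl in place of allyl on the amide-type nitrogen gives a 14-fold lower number from compound 3 to compound 4 (1.14 log units; beyond the scatter), the first step at this position between two actual numbers. Pyridin-3-yl goes against any general gain from an aromatic ring at this nitrogen, and 3-chlorophenyl in its place gives an at least 26-fold lower number from compound 2 to compound 4 (1.42 log units; beyond the scatter), a floor without an exact size. That floor rests on a limit reached by compound 2: the limit of > 50000 nM in this assay, at which 1 of the 4 values shown sits.

Going by these compounds, what a plain phenyl, an amine or carboxylic acid on that ring, or a longer chain in place of allyl would give remains open.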